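The source may report more compounds than this note shows. Statements on the series, on what has been measured and on what is new or still open speak of the compounds shown alone.

Compound 1 `Nc1scc(CN2CCN(c3cccnc3)CC2)c1C(=O)c1ccc(Cl)cc1`: 0%; compound 2 `Nc1scc(CN2CCN(c3c(F)cccc3F)CC2)c1C(=O)c1cccc(C(F)(F)F)c1`: 0%; compound 3 `Nc1scc(CN2CCN(c3cc(F)cc(F)c3)CC2)c1C(=O)c1ccc(Cl)cc1`: 2%.

All three were tested in an assay on CHO cells for displacement of a labelled ligand from adenosine receptor A3 (Homo sapiens), read by scintillation counting, with a stated time of 120 min, tested at 10 uM; on this read-out higher numbers stand for more inhibition at the one concentration tested (going by the name of the read-out) and lower numbers for less inhibition. Compound 1 is level with compound 2, together the two lowest of the three numbers, and compound 3 lies only slightly higher: a number 2 percentage points higher from compound 1 to compound 3 (within the scatter), a difference within the scatter. Compound 4 `Nc1scc(CN2CCN(c3c(F)cc(F)cc3F)CC2)c1C(=O)c1ccc(Cl)cc1` is not yet measured. It differs from compound 1 in one place: 2,4,6-trifluorophenyl in place of pyridin-3-yl on an amine nitrogen in a ring. For the measured compounds named here, the only measured step that bears on this is the one from compound 1 to compound 3, where 3,5-difluorophenyl took the place of the same pyridin-3-yl on the same ring nitrogen and nothing changed beyond the scatter. For compound 4 a step of the same kind is expected, a number 2 percentage points higher from compound 1 to compound 4 (within the scatter). Compound 4 is therefore estimated at 2%, between 0% and 12%.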

Compound 4, a percentage reported as inhibition, at one concentration (the size of the read-out at that concentration, not a potency): 0%
Beside the measured number, compound 4's estimate is 2 percentage points above it, within the range that was stated.
By their numbers in this assay, from the lowest: compounds 1, 2, 4 and 3 (each within the scatter of the next).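

Putting 2,4,6-trifluorophenyl on the ring nitrogen in place of pyridin-3-yl gives no change at the digits printed from compound 1 to compound 4 (within the scatter) in this assay. Putting it in place of 3,5-difluorophenyl gives a number 2 percentage points lower from compound 3 to compound 4 (within the scatter). So, with the rest of the molecule held the same, neither the ring nitrogen of pyridin-3-yl nor this further change in fluorine pattern moves the number beyond the scatter.

As far as these compounds go, whether an amine or a carboxylic acid on that aromatic ring, or a longer chain in its place, would change the number stays open. No measurement at hand speaks to why these numbers stay so close.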